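Benzoyl for methyl at the aryl ether of compound 3

The source may report more compounds than this note shows. Statements on the series, on what has been measured and on what is new or still open speak of the compounds shown alone.

The set comprises three measured compounds and one awaiting measurement. Compound 1 `COC(=O)/C=C/c1cccc(N(Cc2ccc(/C=C/c3cccc(F)c3)cc2)C(=O)C2CCCCC2)c1` and compound 2 `COC(=O)/C=C/c1cccc(N(Cc2ccc(-c3ccc(OC)cc3)cc2)C(=O)C(C)C)c1` both return readable numbers in an assay on isolated protein with Bile acid receptor (Homo sapiens) as the target; a higher number here means that more compound is needed for the effect, a lower number that less compound is needed: compound 1 gives 86 nM, while compound 2 gives 97 nM, the two sitting within the usual scatter of each other. Compound 3 `COC(=O)/C=C/c1cccc(N(Cc2ccc(/C=C/C(=O)OC(C)(C)C)cc2OC)C(=O)C2CCCCC2)c1` stands apart. In this assay compound 3 returns only a limit, > 1000 nM, and not a number. That is the limit described in the limit of > 1000 nM in this assay, at which 1 of the 3 values shown sits, so the position of compound 3 is known only as lying beyond it.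

Compound 4 `COC(=O)/C=C/c1cccc(N(Cc2ccc(/C=C/C(=O)OC(C)(C)C)cc2OC(=O)c2ccccc2)C(=O)C2CCCCC2)c1` differs from compound 3 in one place: benzoyl in place of methyl on an oxygen on an aromatic ring. Within the data shown here, no measured pair in this set shows what such an exchange does in this assay, so no size of step can be read from the data. Because the starting point of compound 3 is itself a limit, > 1000 nM, compound 4 is expected to remain weak, with a step that the limit leaves unreadable from compound 3 to compound 4 being the estimate. Compound 4 is estimated at 1500 nM, within a range from 400 nM to 6000 nM.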

Compound 4, half-maximal effective concentration: > 1000 nM
Compound 4 ended at the assay's limit (the forecaster's own chance of this, stated with the estimate: 60%); the middle value lies beyond the limit too.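

Compound 3 and compound 4 both return only a limit of the assay and not a number, so no step between them can be read: the limit of > 1000 nM in this assay, at which 2 of the 4 values shown sit.

The compounds shown leave open how far past that limit each lies, and whether benzoyl in place of methyl on that oxygen shifts the read-out at all.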